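A few compounds are considered here, and "the series" means these few. Any claim that something is new, unique, unknown or untested is made for them only; others in the source may bear on it.

Measured compounds:
compound 2 `Oc1cccc(-c2cc(-c3ccccc3)nc(-c3ccc(Cl)cc3)c2)c1` gives 11600 nM
compound 3 `Oc1cccc(-c2cc(-c3cccc(Cl)c3)nc(-c3cccs3)c2)c1` gives 3150 nM
compound 1 `Oc1cccc(-c2cc(-c3cccnc3)nc(-c3cccc(Cl)c3)c2)c1` gives "not determined" (no result reported)

These three compounds share a core and differ only in the groups attached to it. In an ADME assay on HEK293 cells (Homo sapiens) for cytotoxicity, read by CCK-8 assay and cell counting, with a stated time of 2 days (on this read-out lower numbers stand for stronger inhibition and higher numbers for weaker inhibition), compound 3 gives 3150 nM, the lower of the two numbers that exist, which means it is the stronger of the two at reducing cell viability. In the same assay compound 2 gives 11600 nM, a higher number, and the gap between compound 3 and compound 2 is larger than the usual scatter of such measurements. Compound 1 contributes no number.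

The unmeasured compound 4 `Oc1cccc(-c2cc(-c3ccccc3)nc(-c3cccc(Cl)c3)c2)c1` is reached from compound 3 by a single change: phenyl in place of thiophen-2-yl on an aromatic carbon. In plain words, a phenyl replaces a thiophen-2-yl on an aromatic carbon, and everything else stays as it is. For the measured compounds named here, no measured pair shows exactly this exchange, so the size of its effect is unknown here. A modest move toward a higher number, a weaker effect in this assay, seems a reasonable expectation, since compound 2, which also carries a phenyl at that position, gives 11600 nM. Compound 4 is therefore expected to reach about 7000 nM, with a plausible range from 2500 nM to 20000 nM. This estimate corresponds to an expected step of a 2.2-fold higher number from compound 3 to compound 4 (0.35 log units; beyond the scatter).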

Compound 4, half-maximal inhibitory concentration: 3120 nM
For compound 4 the middle estimate is 2.2-fold (0.35 log units) above the measured one; the range from low to high includes it.
By their numbers in this assay, from the lowest: compounds 4 and 3 (each within the scatter of the next); then compound 2.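

In this assay, the exchange at this carbon next to the ring nitrogen gives a 1.0-fold lower number from compound 3 to compound 4 (0.00 log units; within the scatter), so the five-membered thiophen-2-yl and the six-membered phenyl cannot be told apart here, at least with a 3-chlorophenyl group on the same ring. Moving the chlorine instead gives a 3.7-fold lower number from compound 2 to compound 4 (0.57 log units; beyond the scatter), so among these compounds the 3-chlorophenyl group goes with a lower number than the 4-chlorophenyl group, which the earlier compounds could not show because they differed in two places. Nothing measured here explains either result. Still open, on these data alone, is whether a non-aromatic group at this carbon, such as an amine or a short alkyl chain, would fit the same picture. Also open, as far as these compounds go, is what a carboxylic acid in place of the chlorine would do to the number.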